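Working notes on compounds 1 to 3, one read-out

This account rests on a few compounds, and the source may have more. Where it says the series, first, only, none or still open, it means among the compounds named here.

Measured so far:
- compound 1 `NC(=O)C1CCN(c2nc(-c3ccccn3)nc3c2CN(Cc2ccccc2)CC3)CC1`: 34.4%
- compound 2 `NC(=O)C1CCN(c2nc(-c3cccnc3)nc3c2CN(Cc2ccccc2)CC3)CC1`: "not active" (no number reported)

In an assay on A549 cells with Cystic fibrosis transmembrane conductance regulator variant F508del (Homo sapiens) as the target, read by fluorescence, with a stated time of 25 min (on this read-out lower numbers stand for smaller maximal responses and higher numbers for larger maximal responses), compound 1 gives 34.4%. Compound 2 carries a pyridin-3-yl group where compound 1 has a different pyridyl attachment. In this assay, within the data shown here, compound 2 is reported as "not active" (no number reported), so no single number stands for it, and no step between the two measured compounds can be given. Compound 2 therefore stands at the bottom of what has been seen, without a value to anchor it.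

Compound 3 `CN(C)CCN1CCN(c2nc(-c3cccnc3)nc3c2CN(Cc2ccccc2)CC3)CC1` keeps the pyridin-3-yl group of compound 2 and changes only one place: 4-(2-(dimethylamino)ethyl)piperazin-1-yl in place of 4-carbamoylpiperidin-1-yl on an aromatic carbon. Among the measured compounds shown here, with compound 2 reported as "not active" (no number reported) in this assay, there is no measured step on which to size this change; any movement in this assay is expected to be small and uncertain in direction, with a real chance that compound 3 is again reported without a number.

For compound 3 in this assay the expected largest response is 15%, estimated to lie between 0% and 40%.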

Compound 3, largest response reached (Emax), in percent of the reference or control that the assay uses: "not active" (no number reported)
For compound 3 the study gives words and no number, so the estimate cannot be set against anything.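

In this assay, among these compounds, compound 2 gives "not active" (no number reported) and compound 3 gives "not active" (no number reported) as well, so no step between the two can be read. No evidence at hand bears on this result.

The compounds shown leave open whether 4-(2-(dimethylamino)ethyl)piperazin-1-yl in place of 4-carbamoylpiperidin-1-yl moves the response at all.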